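Triazole substituent series: hydroxymethyl replaced by ethynyl

The compounds below may be only part of what the source reports. "The series", "measured", "known", "first", "only" and "open" are said of these compounds alone.

Among the compounds with values here, compound 2 `O=C1O[C@@H](Cn2cc(CO)nn2)CN1c1ccc(C2=CCS(=O)(=O)CC2)c(F)c1` gives 47000 nM in an assay for binding affinity to Amine oxidase [flavin-containing] A (Homo sapiens) (a higher number here means a weaker inhibitor, a lower number a stronger inhibitor), and stands highest of the two numbers measured so far, meaning it is the weakest inhibitor of the pair. Within the data shown here, its only neighbour is compound 1 `CC(C)(C)OC(=O)c1cn(C[C@H]2CN(c3ccc(C4=CCS(=O)(=O)CC4)c(F)c3)C(=O)O2)nn1`, which in this assay gives 3500 nM. Among the measured compounds shown here, the single measured step, a 13-fold higher number from compound 1 to compound 2 (1.13 log units; beyond the scatter), is the only guide the series offers.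

Compound 3 `C#Cc1cn(C[C@H]2CN(c3ccc(C4=CCS(=O)(=O)CC4)c(F)c3)C(=O)O2)nn1` is not yet measured; it differs from compound 2 by ethynyl in place of hydroxymethyl on an aromatic carbon. The measured step bears on this change only indirectly: it shows that the group on this carbon of the triazole moves the number a long way, and that the hydroxymethyl gives the weakest reading, but it compares tert-butoxycarbonyl, not ethynyl, so it gives no direct reading of the new group. The ethynyl enters with as many heavy atoms as the hydroxymethyl leaves, yet without its donor and acceptor. Compound 3 is therefore expected to move back toward compound 1 by a step of a 2.4-fold lower number from compound 2 to compound 3 (0.37 log units; beyond the scatter), though well short of it. The estimate for compound 3 in this assay is 20000 nM, with a range from 5000 nM to 60000 nM.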

Compound 3, inhibition constant: > 200000 nM
Compound 3 gave a limit, no number; the forecaster's own chance of this, stated with the estimate: 15%; middle value at least 10-fold (1.00 log units) away from the limit.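

The reading for compound 3 in this assay is a limit, not a number: the limit of > 200000 nM in this assay, at which 1 of the 3 values shown sits. Hydroxymethyl therefore does not mark the low end at this triazole carbon: exchanging it for ethynyl, with 2 heavy atoms on each side, gives an at least 4.2-fold higher number from compound 2 to compound 3 (0.62 log units; beyond the scatter), so the read-out at this position depends on which group sits there, not on the heavy-atom count alone, and removing the hydrogen-bond donor and acceptor of hydroxymethyl brings no return toward compound 1. The full span of the position is now an at least 57-fold higher number from compound 1 to compound 3 (1.75 log units; beyond the scatter), which leaves compound 1, with tert-butoxycarbonyl, as the strongest inhibitor of the three.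

Going by these compounds, the true size of both new steps stays unknown, as compound 3 sets only a lower bound on them, and three groups cannot show which part of tert-butoxycarbonyl carries the advantage of compound 1. A methyl ester, a free carboxylic acid or a plain tert-butyl group on this carbon would separate the carbonyl from the bulky end, and an aminomethyl group would test whether an amine fares any better than hydroxymethyl.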